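Triazole-acetamide series: aryl swap at the triazole carbon

A few compounds are considered here, and "the series" means these few. Any claim that something is new, unique, unknown or untested is made for them only; others in the source may bear on it.

Measured so far:
compound 1 `O=C(Cn1cc(-c2ccccc2Cl)nn1)Nc1nc2ccccc2s1` — > 30000 nM
compound 2 `O=C(Cn1cc(-c2cccs2)nn1)Nc1nc2ccccc2s1` — 21400 nM

In a functional assay on BMDM cells (Mus musculus, strain C57BL/6) for inhibition, with a stated time of 2 days (on this read-out lower numbers stand for stronger inhibition and higher numbers for weaker inhibition), compound 1 gives only a limit, > 30000 nM, at the limit of > 30000 nM in this assay, at which 1 of the 2 values shown sits. Going by the values given here, compound 2 is the one compound with a number in this assay, 21400 nM, and that is the whole of the measured ground. Among the compounds with values here, the one measured step, an at least 1.4-fold lower number from compound 1 to compound 2 (0.14 log units; that floor lies within the scatter), replaced 2-chlorophenyl with thiophen-2-yl and gave a change whose floor lies within the scatter.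

Compound 3 `O=C(Cn1cc(-c2ccc(Cl)cc2)nn1)Nc1nc2ccccc2s1` differs from compound 2 by 4-chlorophenyl in place of thiophen-2-yl on an aromatic carbon. The step from compound 1 to compound 2 is the only one that bears on it, and it runs in the reverse sense: a chlorophenyl comes back, though as 4-chlorophenyl rather than 2-chlorophenyl. Compound 3 is therefore expected to sit near compound 2 or to drift back toward the limit of compound 1, with a 1.3-fold higher number from compound 2 to compound 3 (0.12 log units; within the scatter) as the expected step. The estimate for compound 3 in this assay is 28000 nM, within 12000 nM to 70000 nM, and the chance that the assay again returns only a limit is real.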

Compound 3, half-maximal inhibitory concentration: 130 nM
Compound 3: middle estimate off by 220-fold (2.33 log units), on the high side; measured number outside the range, below it.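

Going by these compounds alone, at this aromatic carbon the read-out in this assay turns out to depend sharply on the group carried: 4-chlorophenyl in place of thiophen-2-yl gives a 160-fold lower number from compound 2 to compound 3 (2.22 log units; beyond the scatter), whereas the one earlier step had a floor within the scatter. A chlorine on the phenyl ring is not enough by itself, as moving from 2-chlorophenyl to 4-chlorophenyl gives an at least 230-fold lower number from compound 1 to compound 3 (2.36 log units; beyond the scatter). That step is only a floor, since compound 1 gives a limit and not a number: the limit of > 30000 nM in this assay, at which 1 of the 3 values shown sits.

The compounds shown leave open whether the chlorine of 4-chlorophenyl is needed at all, or whether plain phenyl, 4-fluorophenyl, 4-methoxyphenyl or 4-carboxyphenyl would read the same way. Also open, going by these compounds, is whether a basic amine on a longer chain at this carbon would be tolerated in this read-out.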